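Aryl swap at the benzylamine: compound 3 to compound 4

The source may hold more compounds than are shown below. What is called first, only, known or untested is meant among the compounds shown, and "the series" means these compounds.

Compound 3 `O=S(=O)(NCCCNCc1ccc(C(F)(F)F)cc1)c1cc(C(F)(F)F)cc(C(F)(F)F)c1` gives 2000 nM in a functional assay on Capan-2 cells (Homo sapiens) for inhibition, read by MTT assay, with a stated time of 72 h (a higher number here means a weaker inhibitor of growth, a lower number a stronger inhibitor of growth), the second highest of the three numbers. Compound 1 `O=S(=O)(NCCCCNCc1ccc(Br)cc1)c1cc(C(F)(F)F)cc(C(F)(F)F)c1` gives 1900 nM and lies within the scatter of compound 3; compound 2 `O=S(=O)(NCCCNCc1cccc(Cl)c1)c1cc(C(F)(F)F)cc(C(F)(F)F)c1` gives 8000 nM, beyond the scatter from compound 3. Compound 4 `COc1ccccc1CNCCCNS(=O)(=O)c1cc(C(F)(F)F)cc(C(F)(F)F)c1` is unmeasured; against compound 3 it carries 2-methoxyphenyl in place of 4-(trifluoromethyl)phenyl on a saturated chain carbon bound to an amine nitrogen. For the measured compounds named here, two measured steps bear on this part of the series: a 4.2-fold higher number from compound 1 to compound 2 (0.62 log units; beyond the scatter) and a 4.0-fold lower number from compound 2 to compound 3 (0.60 log units; beyond the scatter), both modest, and the second alters the same aryl ring at the same place. An aryl exchange here has moved this assay modestly in either direction, so a modest step is expected for compound 4, with the direction uncertain and a slight lean toward a higher number. Compound 4 is estimated at 4000 nM (range 1500 nM to 11000 nM), meaning an expected step of a 2.0-fold higher number from compound 3 to compound 4 (0.30 log units; within the scatter).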

Compound 4, concentration for 50% growth inhibition: 6000 nM
Compound 4: middle estimate off by 1.5-fold (0.18 log units), on the low side; low and high end bracket the measured number.
By their numbers in this assay, from the lowest: compounds 1 and 3 (each within the scatter of the next); then compounds 4 and 2 (each within the scatter of the next).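

In this assay, the exchange of 4-(trifluoromethyl)phenyl for 2-methoxyphenyl on a saturated chain carbon bound to an amine nitrogen gives a 3.0-fold higher number from compound 3 to compound 4 (0.48 log units; beyond the scatter), so the direction at this place is now seen for a second aryl group. The 2-methoxyphenyl and 3-chlorophenyl groups are not separated, with a 1.3-fold lower number from compound 2 to compound 4 (0.12 log units; within the scatter), while the change relative to the 4-bromobenzyl compound gives a 3.2-fold higher number from compound 1 to compound 4 (0.50 log units; beyond the scatter). No measurement available here accounts for these steps. Going by these compounds, how a nitrile or a carboxylic acid on this aryl ring would read remains open, as does whether the 2-methoxybenzyl group behaves alike on a longer chain.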